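Amide aryl swap on the shared core: stability notes

This account rests on a few compounds, and the source may have more. Where it says the series, first, only, none or still open, it means among the compounds named here.

Compound 1 `C[C@@]1(c2cc(NC(=O)c3ncc(OCF)nc3N)ccc2F)C=C(CF)OC(N)=N1` gives 35% in an ADME assay on microsomes from liver (Rattus norvegicus, strain Crj;CD(SD)) for metabolic stability, read by LC-MS, using NADPH, with a stated time of 30 min, tested at 0.1 uM (a lower number here means that less of the compound is left, a higher number that more of the compound is left), numerically the top of the two numbers shown, though the gap to compound 2 is within the scatter. Among the measured compounds shown here, compound 2 `Cc1cc(C#N)cnc1C(=O)Nc1ccc(F)c([C@]2(C)C=C(CF)OC(N)=N2)c1` gives 34% in this assay, and the only measured step is a number 1 percentage points lower from compound 1 to compound 2 (within the scatter). Compound 3 `C[C@@]1(c2cc(NC(=O)c3ncc(C#N)cc3Cl)ccc2F)C=C(CF)OC(N)=N1` differs from compound 1 by 3-chloro-5-cyanopyridin-2-yl in place of 3-amino-5-(fluoromethoxy)pyrazin-2-yl on a carbonyl carbon. For the measured compounds named here, the one step that bears on this, an aryl swap on the same carbonyl carbon, stayed within the scatter, so the expected step is no change at the digits printed from compound 1 to compound 3 (within the scatter), none beyond the scatter. Compound 3 is therefore estimated at 35%, with a range of 20% to 50%.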

Compound 3, percent of the compound remaining: 49%
Beside the measured number, compound 3's estimate is 14 percentage points below it; measured number inside the range.
By their numbers in this assay, from the lowest: compounds 2 and 1 (each within the scatter of the next); then compound 3.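

In this assay the position on the carbonyl carbon proves able to respond: 3-chloro-5-cyanopyridin-2-yl gives a number 14 percentage points higher from compound 1 to compound 3 (beyond the scatter) where the earlier aryl swap stayed within the scatter. Chloro in place of methyl on an aromatic carbon gives a number 15 percentage points higher from compound 2 to compound 3 (beyond the scatter) as a single change, so this one substituent separates the two cyanopyridines. Nothing available here explains either step.

Going by these compounds, whether the gain is specific to chloro stays open, since a bromo or methoxy group on that aromatic carbon would test it. On these data alone, whether chloro gives the same step with the 3-amino-5-(fluoromethoxy)pyrazin-2-yl ring also stays open.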